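Swapping the Halophenyl Cap on a Bulky Triazole Derivative

This account rests on a few compounds, and the source may have more. Where it says the series, first, only, none or still open, it means among the compounds named here.

Compound 1 `O=c1nc2oc(C3CC3)c(C#CC3CC3)c2cn1Cc1cn(-c2ccccc2F)nn1` gives 45900 nM in an ADME assay on WI-38 cells (Homo sapiens) for antiproliferative activity, read by MTT assay, with a stated time of 72 h; a higher number here means a weaker inhibitor, a lower number a stronger inhibitor.
Compound 2 `CCCCCc1ccc(C#Cc2c(-c3ccc(CCCCC)cc3)oc3nc(=O)n(Cc4cn(-c5ccccc5F)nn4)cc23)cc1` gives 7340 nM in this assay.
Compound 3 `CCCCCCc1cc2cn(Cc3cn(-c4ccccc4F)nn3)c(=O)nc2o1` gives 69200 nM in this assay.

Among these three, compound 2 has the lowest number; compound 1 and compound 3 both sit beyond the scatter from it, so compound 2 is the strongest inhibitor of the set. Compound 4 `CCCCCc1ccc(C#Cc2c(-c3ccc(CCCCC)cc3)oc3nc(=O)n(Cc4cn(-c5ccc(Cl)cc5)nn4)cc23)cc1` keeps the whole framework of compound 2 and differs in a single place: 4-chlorophenyl in place of 2-fluorophenyl on an aromatic nitrogen. For the measured compounds named here, no measured pair shows this kind of exchange, so there is no measured step to lean on. The change is expected to be small, a 1.0-fold lower number from compound 2 to compound 4 (0.02 log units; within the scatter) in either direction and not clearly beyond the scatter. Compound 4 is therefore estimated at 7000 nM, with a range from 2500 nM to 20000 nM.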

Compound 4, half-maximal inhibitory concentration: > 100000 nM
Compound 4: a limit, no number; the forecaster's own chance of this, stated with the estimate: 5%; middle value at least 14-fold (1.15 log units) away from the limit.
By their numbers in this assay, from the lowest: compound 2; then compounds 1 and 3 (each within the scatter of the next). At a limit, above all of these: compound 4.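

The halophenyl group on this triazole nitrogen is not a neutral spot, even though the exchange keeps the heavy-atom count the same and adds no hydrogen-bond donors or acceptors: 4-chlorophenyl in place of 2-fluorophenyl gives an at least 13-fold higher number from compound 2 to compound 4 (1.13 log units; beyond the scatter). Compound 4 reads > 100000 nM in this assay, which is a limit and not a number: the limit of > 100000 nM in this assay, at which 1 of the 4 values shown sits.

This single exchange alters both the halogen and its place on the ring, so the two cannot be told apart. From the compounds shown here alone, how a plain phenyl cap, with no halogen, would read on this framework remains open.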